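Naphthyl semicarbazones: phenyl in place of dichlorophenyl

A few compounds are considered here, and "the series" means these few. Any claim that something is new, unique, unknown or untested is made for them only; others in the source may bear on it.

Measured so far:
compound 1 `O=C(N/N=C/c1ccc(Cl)cc1Cl)Nc1cccc2ccccc12` gives 100 mg/kg
compound 2 `COc1cc(/C=N/NC(=O)Nc2cccc3ccccc23)cc(OC)c1OC` gives 100 mg/kg

Both compounds share one core and are read in a functional assay on the whole organism (strain Swiss albino) with Mus musculus as the target, in the maximal electroshock model, with a stated time of 0.5 h; on this read-out higher numbers stand for an effect only at larger amounts of compound and lower numbers for an effect already at smaller amounts. In this assay compound 1 gives 100 mg/kg, and compound 2 gives 100 mg/kg; at the digits shown compound 1 stands level with compound 2, its nearest neighbour, and no change between them lies beyond the scatter. Within the data shown here, no step between two measured compounds that differ in one place is available, so nothing here tells how a change on the aryl ring shifts the read-out.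

Compound 3 `O=C(N/N=C/c1ccccc1)Nc1cccc2ccccc12` is not yet measured. It differs from compound 1 by phenyl in place of 2,4-dichlorophenyl on a carbon with a double bond to nitrogen. Among the measured compounds shown here, with no measured step to lean on, the expected step from compound 1 to compound 3 is a 1.5-fold higher number from compound 1 to compound 3 (0.18 log units; within the scatter), which is taken as no change beyond the scatter, with a slight lean towards a higher dose. The estimate for compound 3 in this assay is 150 mg/kg, in a range from 70 mg/kg to 300 mg/kg.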

Compound 3, minimum effective dose: 300 mg/kg
Estimate against measurement, compound 3: 2.0-fold (0.30 log units) below, and the stated range covers the measured number.
By their numbers in this assay, from the lowest: compounds 1 and 2 (each within the scatter of the next); then compound 3.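

In this assay, phenyl in place of 2,4-dichlorophenyl on a carbon with a double bond to nitrogen gives a 3.0-fold higher number from compound 1 to compound 3 (0.48 log units; beyond the scatter). Among these compounds, this is the only step so far that changes one place, and it shows that the read-out at this position responds to the substituents on the ring: with both chlorines gone, a larger dose is needed for an effect. No measurement bears on the reason for this shift.

Which of the two chlorines carries the step remains open, as does whether a single chlorine would be enough. Also open, as far as these compounds go, is how the read-out would respond at this place to an amine, a carboxylic acid or a longer alkyl chain on the ring.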